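A few compounds are considered here, and "the series" means these few. Any claim that something is new, unique, unknown or untested is made for them only; others in the source may bear on it.

Measured compounds:
compound 1, `Cc1ccccc1-c1nn(-c2ccc(Cl)cc2)cc1CNCCN1CCN(C)CC1`: in an ADME assay on Huh-7 cells (Homo sapiens) for cytotoxicity (a higher number here means that more compound is tolerated, a lower number that less compound is tolerated), compound 1 gives 17000 nM
compound 2, `CN1CCN(CCNCc2cn(-c3ccc(C(F)(F)F)cc3)nc2-c2ccc(OC(F)(F)F)cc2)CC1`: in this assay compound 2 gives 3000 nM

Compound 1 stands highest of the two numbers. Its nearest neighbour is compound 2, whose lower number lies beyond the usual scatter, so compound 1 is the better tolerated of the two. Within the data shown here, no pair of measured compounds differs in one place only, so no single structural step has a measured size here.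

Compound 3, `Cc1ccccc1-c1nn(-c2cccc(C(F)(F)F)c2)cc1CNCCN1CCN(C)CC1`, is not yet measured. Against compound 1 the change is 3-(trifluoromethyl)phenyl in place of 4-chlorophenyl on an aromatic nitrogen. Compound 2 also carries a trifluoromethyl-bearing phenyl on the same aromatic nitrogen, but it differs from compound 1 in more than that one place, so its lower value cannot be attributed to the phenyl substituent alone.

With no clean comparison available, only a modest step is expected for compound 3, downward if anything, and quite possibly not beyond the scatter; the expected step of a 1.7-fold lower number from compound 1 to compound 3 (0.23 log units; within the scatter) reflects this. Compound 3 is thus estimated at 10000 nM in this assay, with a range from 4000 nM to 25000 nM.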

Compound 3, half-maximal cytotoxic concentration: 18000 nM
For compound 3 the middle estimate is 1.8-fold (0.26 log units) below the measured one, within the range that was stated.
By their numbers in this assay, from the lowest: compound 2; then compounds 1 and 3 (each within the scatter of the next).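

Among these compounds, at the aromatic nitrogen, 3-(trifluoromethyl)phenyl in place of 4-chlorophenyl gives a 1.1-fold higher number from compound 1 to compound 3 (0.02 log units; within the scatter), the first single-place step in this assay. With the rest of the core of compound 1 held constant, this position therefore accepts a change of substituent, of substituent location on the phenyl and of heavy-atom count with no difference beyond the scatter. Compound 2 differs from compound 3 in more than one place, so this step does not account for the value of compound 2, and no available measurement offers an explanation for the step itself.

Still open, from the compounds shown here alone, is whether this tolerance extends to quite different groups on the same nitrogen, such as an unsubstituted phenyl, a 4-methoxyphenyl or a pyridine ring. Also open, going by these compounds, is how the 2-methylphenyl group and the side chain ending in the methylpiperazine contribute, for example with a plain phenyl at the first of these places or a morpholine at the second.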